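Cytotoxicity limits across a cinnamate ester pair and glucoside

The source may hold more compounds than are shown below. What is called first, only, known or untested is meant among the compounds shown, and "the series" means these compounds.

Measured so far, all in an ADME assay on HepG2 2.2.15 cells (Homo sapiens) for cytotoxicity, read by MTT assay; a higher number here means that more compound is tolerated, a lower number that less compound is tolerated:
compound 1 `COc1cccc(/C=C/C(=O)Oc2ccc(C(C)=O)cc2)c1`: > 2780000 nM
compound 2 `CC(=O)c1ccc(OC(=O)/C=C/c2cccc(F)c2)cc1`: > 3100000 nM
compound 3 `COc1cccc(/C=C/C(=O)OC[C@H]2O[C@@H](Oc3ccc(C(C)=O)cc3)[C@H](O)[C@@H](O)[C@@H]2O)c1`: > 1510000 nM

In this assay compound 1 gives only a limit, > 2780000 nM. Compound 2 likewise gives only a limit, > 3100000 nM. The change between them is fluoro in place of methoxy on an aromatic carbon, and in this assay it reads as a step that the two limits leave unreadable from compound 1 to compound 2, because the limit of > 2780000 nM in this assay, at which 1 of the 3 values shown sits, and the limit of > 3100000 nM in this assay, at which 1 of the 3 values shown sits, both cap the numbers.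

Compound 3 `COc1cccc(/C=C/C(=O)OC[C@H]2O[C@@H](Oc3ccc(C(C)=O)cc3)[C@H](O)[C@@H](O)[C@@H]2O)c1` differs from compound 1 by a larger part of the molecule; the difference between the two cores is not broken down here. In this assay compound 3 also gives only a limit, > 1510000 nM, because the limit of > 1510000 nM in this assay, at which 1 of the 3 values shown sits, is where its value sits.

Compound 4 `CC(=O)c1ccc(O[C@@H]2O[C@H](COC(=O)/C=C/c3cccc(F)c3)[C@@H](O)[C@H](O)[C@H]2O)cc1` is not yet measured. It differs from compound 3 by fluoro in place of methoxy on an aromatic carbon, the same change that takes compound 1 to compound 2. Within the data shown here, since every value so far is a limit, the step is expected to stay unreadable, and the estimated step is a step that the limit leaves unreadable from compound 3 to compound 4. Compound 4 is expected to give about 2000000 nM, between 500000 nM and 5000000 nM, most likely reported again as a limit.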

Compound 4, half-maximal cytotoxic concentration: 828000 nM
The estimate for compound 4 lay 2.4-fold (0.38 log units) above the measured number, within the range that was stated.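

Among these compounds, on the second core, fluoro in place of methoxy gives an at least 1.8-fold lower number from compound 3 to compound 4 (0.26 log units; that floor lies within the scatter) in this assay, and compound 4 is the only one of the four compounds with an actual number rather than a limit. The same change on the first core cannot be read, with a limit at both ends of that pair. The series therefore does not show that the change carries from one core to the other: neither the size nor the direction of the step on the first core is known, and the step on the second core is secure only as a floor that lies within the scatter.

The compounds shown leave open how a different group on the same aromatic carbon, such as a chloro group, a trifluoromethyl group or an amine, would read in this assay on either core. They also leave open how an amide in place of the ester link would read there.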